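Cyclobutyl to isopropylamino on the acyl amide of compound 3

The source may hold more compounds than are shown below. What is called first, only, known or untested is meant among the compounds shown, and "the series" means these compounds.

The series shares a core carrying two amide-type nitrogens, each acylated. Compound 1 `O=C(Nc1ccc2nc(NC(=O)C3CCCCC3)sc2c1)c1cccnc1Cl` is acylated on one side with cyclohexylcarbonyl and on the other with 2-chloropyridin-3-yl carbonyl; in a functional assay on WI-38 VA13 cells (Homo sapiens) for cytotoxicity (a lower number here means that less compound is needed, a higher number that more compound is needed for the effect), compound 1 gives 0.075 ug/mL. Among the measured compounds shown here, compound 2 `Cc1nc(C)c(C(=O)Nc2ccc3nc(NC(=O)C4CCCCC4)sc3c2)s1` keeps the cyclohexylcarbonyl side and in this assay gives 0.39 ug/mL; the one step between them reads a 5.2-fold higher number from compound 1 to compound 2 (0.72 log units; beyond the scatter). Compound 3 `O=C(Nc1ccc2nc(NC(=O)C3CCC3)sc2c1)c1c(Cl)cccc1Cl` carries cyclobutylcarbonyl on one nitrogen and 2,6-dichlorobenzoyl on the other, and in this assay compound 3 gives 0.013 ug/mL, the lowest of the three numbers, beyond the scatter from both others.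

Compound 4 `CC(C)NC(=O)Nc1nc2ccc(NC(=O)c3c(Cl)cccc3Cl)cc2s1` differs from compound 3 in one place: isopropylamino in place of cyclobutyl on a carbonyl carbon. For the measured compounds named here, no measured pair differs at that position, so the size of this step cannot be read from a measured step; the only measured step, from compound 1 to compound 2, concerns the other carbonyl. The dichlorobenzoyl side, which compound 3 shows to be favourable, is unchanged. Compound 4 is therefore expected to stay close to compound 3, with a step of a 1.9-fold higher number from compound 3 to compound 4 (0.28 log units; within the scatter) toward a somewhat higher number, and its estimated value is 0.025 ug/mL, ranging from 0.008 ug/mL to 0.08 ug/mL.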

Compound 4, half-maximal effective concentration: 0.03 ug/mL
Beside the measured number, compound 4's estimate is 1.2-fold (0.08 log units) below it; low and high end bracket the measured number.
By their numbers in this assay, from the lowest: compound 3; then compound 4; then compound 1; then compound 2.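

Among the compounds shown here, this is the first measured step at this position, on a carbonyl carbon whose other neighbour is an amide-type nitrogen, and the 2,6-dichlorobenzoyl side stays fixed throughout. In this assay the change from cyclobutyl to isopropylamino gives a 2.3-fold higher number from compound 3 to compound 4 (0.36 log units; beyond the scatter), so the position responds measurably but modestly when a four-membered carbon ring gives way to an open group that brings a nitrogen and one hydrogen-bond donor. No supporting data bear on the origin of this shift, so it stands here as an observation only.

The step changes the ring and the linking nitrogen together, so the compounds shown leave open which of the two accounts for the shift; isopropyl on the same carbonyl would keep the open shape without the nitrogen, whereas cyclobutylamino would keep the ring and add the nitrogen. They also leave open how far this position tolerates larger or charged groups, such as a morpholine or a carboxylic acid, and whether the step would keep its size with the 2-chloropyridin-3-yl group on the other carbonyl.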